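Methylsulfanyl Benzyl Variant of a Hydroxamate Sulfonamide

The compounds below may be only part of what the source reports. "The series", "measured", "known", "first", "only" and "open" are said of these compounds alone.

Compound 3 `COc1ccc(S(=O)(=O)N(Cc2ccc(Cl)c(Cl)c2)[C@H](C)C(=O)NO)cc1` gives 120 nM in an assay on isolated protein for inhibition of bone morphogenetic protein 1 (Homo sapiens) (on this read-out higher numbers stand for weaker inhibition and lower numbers for stronger inhibition), the second highest of the three numbers measured; its nearest neighbour is compound 2 `COc1ccc(S(=O)(=O)N(Cc2cccc(Br)c2)[C@H](C)C(=O)NO)cc1` with 93 nM, and the furthest is compound 1 `COc1ccc(S(=O)(=O)N(Cc2ccc(C(C)C)cc2)[C@H](C)C(=O)NO)cc1` with 230 nM. Compound 4 `COc1ccc(S(=O)(=O)N(Cc2ccc(SC)cc2)[C@H](C)C(=O)NO)cc1` differs from compound 3 by 4-(methylsulfanyl)phenyl in place of 3,4-dichlorophenyl on a saturated chain carbon bound to a sulfonamide nitrogen. The steps already seen all concern exchanges at the same place: a 2.5-fold lower number from compound 1 to compound 2 (0.39 log units; beyond the scatter), a 1.9-fold lower number from compound 1 to compound 3 (0.28 log units; within the scatter) and a 1.3-fold higher number from compound 2 to compound 3 (0.11 log units; within the scatter). Since these exchanges moved this assay only modestly, and only one of them beyond the scatter, compound 4 is expected to shift little, a 1.3-fold higher number from compound 3 to compound 4 (0.10 log units; within the scatter), with no clear direction. Compound 4 is therefore estimated at 150 nM, within a range of 70 nM to 330 nM.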

Compound 4, half-maximal inhibitory concentration: 80 nM
Estimate against measurement, compound 4: 1.9-fold (0.27 log units) above, and the stated range covers the measured number.
By their numbers in this assay, from the lowest: compounds 4, 2, 3 and 1 (each within the scatter of the next, the first and the last beyond it).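

In this assay, no halogen is needed at this place on a saturated chain carbon bound to a sulfonamide nitrogen: a 1.5-fold lower number from compound 3 to compound 4 (0.18 log units; within the scatter) and a 1.2-fold lower number from compound 2 to compound 4 (0.07 log units; within the scatter) both stay within the scatter. Exchanging isopropyl for methylsulfanyl on an aromatic carbon is a different matter, giving a 2.9-fold lower number from compound 1 to compound 4 (0.46 log units; beyond the scatter), which lies beyond it. Nothing available explains these results. The compounds shown leave open how an ethylsulfanyl, methylsulfonyl or dimethylamino group would behave in place of methylsulfanyl, and whether a carboxylic acid on the benzyl ring would be accepted.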